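Methyl-amide to ethyl-amide change on the shared core

A few compounds are considered here, and "the series" means these few. Any claim that something is new, unique, unknown or untested is made for them only; others in the source may bear on it.

In a functional assay on U-87MG ATCC cells for antiproliferative activity against U-87 MG (Homo sapiens), read by MTT assay, with a stated time of 72 h (a lower number here means a stronger inhibitor, a higher number a weaker inhibitor), compound 1 `CNC(=O)c1cc(Oc2ccc(NC(=O)c3cc4cccnc4n(-c4ccc(F)cc4)c3=O)cc2)ccn1` gives 2910 nM, the lowest of the two numbers available. Compound 2 `CNC(=O)c1cc(Oc2ccc(NC(=O)c3cc4cccnc4n(-c4ccc(C(F)(F)F)cc4Cl)c3=O)cc2)ccn1` is weaker, with 19800 nM; the step of a 6.8-fold higher number from compound 1 to compound 2 (0.83 log units; beyond the scatter) concerns the aryl group on the ring nitrogen. Compound 3 `CNC(=O)c1cc(Oc2ccc(NC(=O)c3cc4cccnc4n(-c4ccc(F)c(Cl)c4)c3=O)cc2)ccn1` has no reported result in this assay, its entry reading "not determined" (no result reported). Compound 4 `CCNC(=O)c1cc(Oc2ccc(NC(=O)c3cc4cccnc4n(-c4ccc(F)cc4)c3=O)cc2)ccn1` differs from compound 1 only by methyl in place of hydrogen on a saturated chain carbon bound to an amide-type nitrogen. For the measured compounds named here, no measured step touches this amide substituent; the single known step lies elsewhere on the core and does not bear on it. For compound 4 the step of a 1.2-fold higher number from compound 1 to compound 4 (0.08 log units; within the scatter) is therefore expected to stay within the scatter. The estimate for compound 4 is 3500 nM, with a range from 1200 nM to 10000 nM.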

Compound 4, half-maximal inhibitory concentration: 1130 nM
For compound 4 the middle estimate is 3.1-fold (0.49 log units) above the measured one; measured number below the stated range.
By their numbers in this assay, from the lowest: compound 4; then compound 1; then compound 2.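

In this assay, methylcarbamoyl to ethylcarbamoyl gives a 2.6-fold lower number from compound 1 to compound 4 (0.41 log units; beyond the scatter). For the compounds shown here, this shows that the amide substituent, which no earlier step touched, is a place where one added carbon moves the number, and here it moves it down, whereas the only earlier step, on the aryl group, moved it up. No measurement shown accounts for this step.

As far as these compounds go, whether a longer chain such as propyl, or a cyclopropyl group, lowers the number further remains open. So does whether ethyl has the same effect alongside the 2-chloro-4-(trifluoromethyl)phenyl group of compound 2.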